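Pyridin-2-yl in place of 4-aminophenyl on the shared core

The source may report more compounds than this note shows. Statements on the series, on what has been measured and on what is new or still open speak of the compounds shown alone.

Compound 1 `Cc1ccccc1-c1nnc(SCc2ccc(Cl)nc2)o1`: 8.51 ug/mL
Compound 2 `Nc1ccc(-c2nnc(SCc3ccc(Cl)nc3)o2)cc1`: 8.48 ug/mL
Compound 3 `Clc1ccc(CSc2nnc(-c3ccccn3)o2)cn1`: not yet measured

In a functional assay on SGC-7901 cells (Homo sapiens) for antiproliferative activity, read by MTT assay, with a stated time of 48 h (a lower number here means a stronger inhibitor, a higher number a weaker inhibitor), compound 2 stands level with compound 1, within the scatter. Compound 3 differs from compound 2 as follows: pyridin-2-yl in place of 4-aminophenyl on an aromatic carbon. Within the data shown here, only one measured step bears on this change, a replacement at the same place on the shared core: a 1.0-fold lower number from compound 1 to compound 2 (0.00 log units; within the scatter). Among the measured compounds shown here, that single step stayed within the scatter, and no compound with pyridin-2-yl has been measured, so no step beyond the scatter is expected. The expected result is a 1.1-fold higher number from compound 2 to compound 3 (0.03 log units; within the scatter). The estimate for compound 3 is 9 ug/mL, with an expected range of 4.5 ug/mL to 18 ug/mL.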

Compound 3, half-maximal inhibitory concentration: 12.6 ug/mL
The estimate for compound 3 lay 1.4-fold (0.15 log units) below the measured number; measured number inside the range.
By their numbers in this assay, from the lowest: compounds 2, 1 and 3 (each within the scatter of the next).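

In this assay, pyridin-2-yl in place of 4-aminophenyl gives a 1.5-fold higher number from compound 2 to compound 3 (0.17 log units; within the scatter), and pyridin-2-yl in place of 2-methylphenyl gives a 1.5-fold higher number from compound 1 to compound 3 (0.17 log units; within the scatter). This position on the shared core therefore accepts a six-membered aromatic ring with a hetero atom and 0 hydrogen-bond donors, with no step beyond the scatter among the three compounds. No supporting data bear on this result.

From the compounds shown here alone, whether any group at this place moves the number beyond the scatter remains open. A carboxylic acid on the phenyl ring or a non-aromatic group such as cyclohexyl would test this.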